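The source may report more compounds than this note shows. Statements on the series, on what has been measured and on what is new or still open speak of the compounds shown alone.

Values in a functional assay for inhibition, with Homo sapiens as the target; on this read-out higher numbers stand for weaker binding and lower numbers for tighter binding:
Compound 1 `O=C(O)CC/C=C\CC1COC(c2ccsc2)OC1c1cccnc1` gives 1580 nM
Compound 2 `O=C(O)CC/C=C\CC1COC(c2cccs2)OC1c1cccnc1` gives 1000 nM
Compound 3 `O=C(O)CC/C=C\CC1COC(c2cccc3ccccc23)OC1c1cccnc1` gives 631 nM

Compound 3 stands apart from compound 1 (a 2.5-fold lower number from compound 1 to compound 3 (0.40 log units; beyond the scatter)) but cannot be told from compound 2 (a 1.6-fold lower number from compound 2 to compound 3 (0.20 log units; within the scatter)). Compound 4 `CC(C)(Oc1ccccc1)C1OCC(C/C=C\CCC(=O)O)C(c2cccnc2)O1` keeps the shared core and changes only the group on the saturated ring carbon between two ring oxygen atoms (a group of 10 heavy atoms (9 carbon, 1 oxygen; one six-membered aromatic ring of carbon only) in place of a group of 10 heavy atoms (10 carbon; 2 six-membered aromatic rings of carbon only), on a saturated ring carbon). The measured steps that bear on this change are the swaps at that same carbon. Besides the two above, there is one more within the scatter (a 1.6-fold lower number from compound 1 to compound 2 (0.20 log units; within the scatter)), so the largest of the three is only modest. Going by the values given here, none of the measured compounds carries an oxygen atom in the group at this carbon, so these steps are only a loose guide and the range is kept wide. No step beyond the scatter is expected in this assay, and the expected change is small (a 1.3-fold higher number from compound 3 to compound 4 (0.10 log units; within the scatter)). Compound 4 is estimated at 800 nM (expected range 250 nM to 2500 nM).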

Compound 4, dissociation constant: 75.9 nM
Compound 4: middle estimate off by 11-fold (1.02 log units), on the high side; measured number outside the range, below it.
By their numbers in this assay, from the lowest: compound 4; then compounds 3, 2 and 1 (each within the scatter of the next, the first and the last beyond it).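

In this assay, the earlier swaps at the saturated ring carbon between two ring oxygen atoms moved the number little, but the group of compound 4 gives an 8.3-fold lower number from compound 3 to compound 4 (0.92 log units; beyond the scatter), and the steps from the two thiophene compounds are larger still: a 13-fold lower number from compound 2 to compound 4 (1.12 log units; beyond the scatter) and a 21-fold lower number from compound 1 to compound 4 (1.32 log units; beyond the scatter). This position can therefore respond far more strongly than the three aromatic groups suggested, and heavy-atom count alone does not set the number: naphthalen-1-yl and the entering group both have 10 heavy atoms, yet the step between them lies beyond the scatter. Nothing available here explains this step.

The compounds shown leave open which feature of the entering group goes with the lower number, as its oxygen atom and its single aromatic ring enter together. A group with a methylene in place of that oxygen, or with an amine there, would help to separate the two.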